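This account rests on a few compounds, and the source may have more. Where it says the series, first, only, none or still open, it means among the compounds named here.

Compound 1 `CCCc1cc(Cn2c(CC)nc3c(C)cc(C)nc32)cc(CCC)c1OC(C(=O)O)c1ccccc1Cl` gives 3500 nM in an assay on isolated protein for displacement of a labelled ligand from Type-2 angiotensin II receptor (Rattus norvegicus); a lower number here means a stronger inhibitor, a higher number a weaker inhibitor. Compound 2 `CCCc1cc(Cn2c(CC)nc3c(C)cc(C)nc32)cc(CCC)c1OC(C(=O)O)c1ccccc1`, which carries hydrogen in place of the chloro on the aromatic carbon, gives 2600 nM in the same assay. For the measured compounds named here, the step of a 1.3-fold lower number from compound 1 to compound 2 (0.13 log units; within the scatter) is the only one measured so far, and on the two numbers known compound 2 stands at the lower end, with compound 1 as its only neighbour, the two values lying within the scatter of one another.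

Compound 3 `CCCc1cc(Cn2c(CC)nc3c(C)cc(C)nc32)cc(CCC)c1OC(C(=O)O)c1ccc(C)cc1` is the next compound to be examined. Its difference from compound 2 is methyl in place of hydrogen on an aromatic carbon: a methyl in place of hydrogen on an aromatic carbon of the six-membered carbon-only ring, para to a large group. Going by the values given here, the only step that bears on it, a 1.3-fold lower number from compound 1 to compound 2 (0.13 log units; within the scatter), shows that changing a substituent on this ring left the number essentially unchanged, though that change concerned a different group at a different place. On this evidence a step of a 1.0-fold lower number from compound 2 to compound 3 (0.02 log units; within the scatter) in this assay is expected for compound 3, with no direction beyond the scatter, giving an estimated value of 2500 nM, in the range 900 nM to 7000 nM.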

Compound 3, half-maximal inhibitory concentration: 400 nM
Compound 3: the middle estimate sits 6.3-fold (0.80 log units) above what was measured; the measured number lies below the stated range.
By their numbers in this assay, from the lowest: compound 3; then compounds 2 and 1 (each within the scatter of the next).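

In this assay, methyl in place of hydrogen on an aromatic carbon of the six-membered ring, para to a large group, gives a 6.5-fold lower number from compound 2 to compound 3 (0.81 log units; beyond the scatter), a modest step but one beyond the scatter. This shows that the number can respond to a change on this ring, which a 1.3-fold lower number from compound 1 to compound 2 (0.13 log units; within the scatter), a step within the scatter, did not reveal. Exchanging 2-chlorophenyl for 4-methylphenyl gives an 8.8-fold lower number from compound 1 to compound 3 (0.94 log units; beyond the scatter), also beyond the scatter, so compound 3 has the lowest number of the three, though nothing available explains why this methyl has this effect.

The compounds shown leave open whether the drop belongs to methyl itself or would also follow from another group at this place, such as ethyl, methoxy or a carboxylic acid. They also leave open whether it depends on the place, since a single methyl at one position cannot show how the same group would behave elsewhere on the ring, as in 2-methylphenyl.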